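Trimming the Isopropyl of Compound 1 to Methyl

This account rests on a few compounds, and the source may have more. Where it says the series, first, only, none or still open, it means among the compounds named here.

Compound 1 `COc1ccc(Nc2nc(SCc3cn(CC(=O)NC(=O)Nc4ccccn4)nn3)nc(-c3ccc(C(C)C)cc3)c2C#N)cc1` was examined in a functional assay on MGC-803 cells (Homo sapiens) for inhibition, read by MTT assay, with a stated time of 72 h; a higher number here means a weaker inhibitor, a lower number a stronger inhibitor. In this assay compound 1 gives only a limit, > 64000 nM. Its companion compound 2 `Cc1cccc(Nc2nc(SCc3cn(CC(=O)NC(=O)Nc4ccccn4)nn3)nc(-c3ccc(C(C)C)cc3)c2C#N)c1` gives 25300 nM in this assay, and the step of an at least 2.5-fold lower number from compound 1 to compound 2 (0.40 log units; beyond the scatter) concerns the amine-bound aryl group, so it does not bear on the change considered here. Compound 3 `COc1ccc(Nc2nc(SCc3cn(CC(=O)NC(=O)Nc4ccccn4)nn3)nc(-c3ccc(C)cc3)c2C#N)cc1` differs from compound 1 by methyl in place of isopropyl on an aromatic carbon. Among the measured compounds shown here, compound 1 sits at the limit (the limit of > 64000 nM in this assay, at which 1 of the 2 values shown sits), and no measured step speaks to this change. Compound 3 is therefore expected to stay weak, with an estimated step that the limit leaves unreadable from compound 1 to compound 3. In this assay compound 3 is expected near 80000 nM, within 20000 nM to 300000 nM.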

Compound 3, half-maximal inhibitory concentration: 1700 nM
Compound 3: middle estimate off by 47-fold (1.67 log units), on the high side, and the stated range ends above it.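

In this assay, replacing 4-isopropylphenyl with 4-methylphenyl gives an at least 37-fold lower number from compound 1 to compound 3 (1.57 log units; beyond the scatter), which shows that this place on the aromatic ring, not only the amine-bound aryl group, can shift the number, and that this one change is enough for a large step. The true size of the step stays unknown, and only its lower bound can be read, since compound 1 stands at a limit: the limit of > 64000 nM in this assay, at which 1 of the 3 values shown sits.

The compounds shown leave open how an ethyl or a methoxy group would read at this place. They also leave open whether 4-methylphenyl here and 3-methylphenyl on the nitrogen would combine.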